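The source may hold more compounds than are shown below. What is called first, only, known or untested is meant among the compounds shown, and "the series" means these compounds.

Working notes on the series.

Compound 1 `COc1cc2c(Oc3ccc(NC(=O)c4nnn(-c5ccccc5)c4C)cc3F)ccnc2cc1OCCCN1CCCCC1` is the reference point here. Within the data shown here, in a functional assay on U-87MG ATCC cells (Homo sapiens) for cytotoxicity, read by MTT assay, with a stated time of 72 h (a lower number here means a stronger inhibitor, a higher number a weaker inhibitor), compound 1 gives 1130 nM, the lowest of the two numbers measured so far, though its nearest neighbour sits within the scatter: compound 2 `COc1cc2c(Oc3ccc(NC(=O)c4nnn(-c5ccccc5C(F)(F)F)c4C)cc3F)ccnc2cc1OCCCN1CCCCC1` gives 1150 nM, and a 1.0-fold higher number from compound 1 to compound 2 (0.01 log units; within the scatter) shows that trifluoromethyl in place of hydrogen on the aromatic carbon leaves the read-out essentially unchanged.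

Compound 3 `COc1cc2c(Oc3ccc(NC(=O)c4nnn(-c5ccccc5)c4C)cc3F)ccnc2cc1OCCCN1CCC(C)CC1` differs from compound 1 by methyl in place of hydrogen on a saturated ring carbon, three ring bonds from the ring nitrogen; put one bond further out, piperidin-1-yl becomes 4-methylpiperidin-1-yl. Among the measured compounds shown here, no measured step touches this ring; the single step available concerns an aromatic carbon elsewhere in the molecule and was itself within the scatter, so it gives no direct guidance. With nothing to suggest otherwise, the expected step in this assay is none beyond the scatter, a 1.0-fold lower number from compound 1 to compound 3 (0.01 log units; within the scatter). Compound 3 is therefore estimated at 1100 nM, with a range of 500 nM to 2500 nM.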

Compound 3, half-maximal inhibitory concentration: 1240 nM
Compound 3: middle estimate off by 1.1-fold (0.05 log units), on the low side, within the range that was stated.
By their numbers in this assay, from the lowest: compounds 1, 2 and 3 (each within the scatter of the next).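

The piperidin-1-yl ring now has a measured step of its own: in this assay, 4-methylpiperidin-1-yl in place of piperidin-1-yl gives a 1.1-fold higher number from compound 1 to compound 3 (0.04 log units; within the scatter). Among these compounds, a methyl on this saturated ring carbon, three ring bonds from the ring nitrogen, therefore leaves the read-out within the scatter, something the earlier compounds, which differ only on an aromatic carbon, could not show. No available evidence bears on this result.

One methyl says little about other groups on the same ring carbon, so a hydroxyl, a primary amine or a longer chain such as n-butyl could still behave differently. Going by these compounds, it also remains open whether the trifluoromethyl and methyl changes, each within the scatter alone, would stay there when combined in one molecule.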